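The source may report more compounds than this note shows. Statements on the series, on what has been measured and on what is new or still open speak of the compounds shown alone.

Measured so far:

Compound 1 `Cc1ccc2c(=O)c(CSC(=S)N3CCCCC3)coc2c1` — 900 nM
Compound 2 `O=c1c(CSC(=S)N2CCCC2)coc2ccccc12` — 3600 nM

In a functional assay on HEp-2 cells (Homo sapiens) for antiproliferative activity, read by MTT assay, with a stated time of 72 h (a lower number here means a stronger inhibitor, a higher number a weaker inhibitor), compound 2 gives 3600 nM, the highest of the two numbers measured to date. Its nearest neighbour, compound 1, gives 900 nM in this assay, a lower number, and the gap between the two lies beyond the usual scatter. Among the measured compounds shown here, compound 1 and compound 2 differ in more than one place, so no single step connects them; the two values can only be set side by side.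

Compound 3 `Cc1ccc2c(=O)c(CSC(=S)N3CCCC3)coc2c1` is the next compound for this assay. It differs from compound 2 in one place: methyl in place of hydrogen on an aromatic carbon. Compound 1 carries the same methyl and gives the lower number, so a decrease from compound 2 to compound 3 is expected, probably beyond the scatter but smaller than the whole gap to compound 1, since that gap also contains the change in ring size. The expected step is a 2.3-fold lower number from compound 2 to compound 3 (0.35 log units; beyond the scatter). For compound 3 in this assay the estimate is 1600 nM, with a range from 600 nM to 4000 nM.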

Compound 3, half-maximal inhibitory concentration: 3600 nM
Beside the measured number, compound 3's estimate is 2.3-fold (0.35 log units) below it, and the stated range covers the measured number.
By their numbers in this assay, from the lowest: compound 1; then compounds 2 and 3 (each within the scatter of the next).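

In this assay, among the compounds shown here, the single step at this position reads no change at the digits printed from compound 2 to compound 3 (within the scatter) for methyl in place of hydrogen on an aromatic carbon, so with pyrrolidin-1-yl on the thiocarbonyl carbon this methyl leaves the antiproliferative number unchanged. For the compounds shown here, the ring change can now be read on its own and gives a 4.0-fold higher number from compound 1 to compound 3 (0.60 log units; beyond the scatter) with the methyl held constant, and this pyrrolidin-1-yl in place of piperidin-1-yl step is the only single-place step so far that lies beyond the scatter. Nothing measured on these compounds points to a cause for either step.

Going by these compounds alone, whether the methyl step is equally flat with piperidin-1-yl on the thiocarbonyl carbon stays open, since only two single-place steps can be read and both involve compound 3. Also open, from the compounds shown here alone, are a morpholin-4-yl or azepan-1-yl ring on the thiocarbonyl carbon, and a chlorine, a methoxy group or a longer alkyl chain in place of the methyl on the same aromatic carbon.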